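Swapping the trifluoromethyl carbinol for a sulfoximine

The source may hold more compounds than are shown below. What is called first, only, known or untested is meant among the compounds shown, and "the series" means these compounds.

Compound 3 `CC#CCC(O)(c1ccc(N2CCN(S(=O)(=O)c3ccc(N)nc3)C[C@@H]2C#CC)cc1)C(F)(F)F` gives 137 nM in an assay on cells (Hepatocyte) for inhibition of glucokinase regulatory protein (Mus musculus), with stated times of 20 min and 40 min (on this read-out lower numbers stand for an effect already at smaller amounts and higher numbers for an effect only at larger amounts of compound), which puts it within the scatter of compound 1 `C#CCC(O)(c1ccc(N2CCN(S(=O)(=O)c3ccc(N)nc3)C[C@@H]2C#CC)cc1)C(F)(F)F` at 130 nM, the pair differing only as a 1.1-fold higher number from compound 1 to compound 3 (0.02 log units; within the scatter). Compound 2 `CC#C[C@H]1CN(S(=O)(=O)c2ccc(N)nc2)CCN1c1ccc(S(=O)(=O)Nc2ccccc2)cc1` reached only the assay limit > 12500 nM, as noted in the limit of > 12500 nM in this assay, at which 1 of the 3 values shown sits. Compound 4 `CC#C[C@H]1CN(S(=O)(=O)c2ccc(N)nc2)CCN1c1ccc(S(C)(=N)=O)cc1` differs from compound 3 in that (a group of 4 heavy atoms (1 carbon, 1 nitrogen, 1 oxygen, 1 sulfur; no ring) in place of a group of 10 heavy atoms (6 carbon, 1 oxygen, 3 fluorine; no ring), on an aromatic carbon). The bearing steps are an at least 96-fold higher number from compound 1 to compound 2 (1.98 log units; beyond the scatter) and an at least 91-fold lower number from compound 2 to compound 3 (1.96 log units; beyond the scatter): both show that exchanging the tertiary alcohol group for a sulfur-bearing substituent on that aromatic carbon costs a large amount of potency. Since the sulfoximine of compound 4 likewise removes that alcohol group, a large upward step a 26-fold higher number from compound 3 to compound 4 (1.41 log units; beyond the scatter) is expected, and compound 4 is estimated at 3500 nM, between 800 nM and 12500 nM.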

Compound 4, half-maximal effective concentration: 704 nM
For compound 4 the middle estimate is 5.0-fold (0.70 log units) above the measured one; the whole stated range lies above it.
By their numbers in this assay, from the lowest: compounds 1 and 3 (each within the scatter of the next); then compound 4. At a limit, above all of these: compound 2.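

In this assay, the sulfoximine shows that activity on this aromatic carbon survives loss of the trifluoromethyl carbinol, with the modest steps of a 5.1-fold higher number from compound 3 to compound 4 (0.71 log units; beyond the scatter) and a 5.4-fold higher number from compound 1 to compound 4 (0.73 log units; beyond the scatter). A sulfur-bearing group here therefore need not cost as much as that of compound 2, as the large step of an at least 17-fold lower number from compound 2 to compound 4 (1.24 log units; beyond the scatter) shows. That step is only a bound, as compound 2 stands at a limit and not at a number: the limit of > 12500 nM in this assay, at which 1 of the 4 values shown sits.

From the compounds shown here alone, whether a methyl sulfone would behave like the sulfoximine remains open. So does the effect of a methyl group on the sulfoximine nitrogen.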